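The compounds below may be only part of what the source reports. "The series", "measured", "known", "first", "only" and "open" are said of these compounds alone.

Measured compounds:
compound 1, `O=S(=O)(Nc1ccc2oc(-c3ccccc3)nc2c1)c1cccc(C(F)(F)F)c1`, > 100000 nM
compound 2, `Cc1ccc(S(=O)(=O)Nc2ccc(-c3nc4ccccc4o3)cc2)cc1`, > 100000 nM
compound 3, `O=S(=O)(Nc1ccc(-c2nc3cc(NS(=O)(=O)c4cccs4)ccc3o2)cc1)c1cccs1`, 40000 nM

In an assay on cells for inhibition of HSP60/HSP10 (Homo sapiens), with a stated time of 60 min (a higher number here means a weaker inhibitor, a lower number a stronger inhibitor), compound 2 gives > 100000 nM, which is a limit of the assay and not a number. Compound 1 likewise gives > 100000 nM in this assay, again a limit. Only compound 3 returns a number in this assay, at 40000 nM. Compound 2 therefore stands at the weak end of what is shown, sharing the limit described by the limit of > 100000 nM in this assay, at which 2 of the 3 values shown sit, and no step between two measured compounds is available to guide the next change.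

Compound 4, `O=S(=O)(Nc1ccc(-c2nc3ccccc3o2)cc1)c1cccc(O)c1`, differs from compound 2 in one place: 3-hydroxyphenyl in place of 4-methylphenyl on a sulfonyl sulfur. Nothing measured here speaks to what a hydroxyl on that ring does, so the expectation rests on the standing of compound 2 alone. The estimated step of an at least 1.2-fold lower number from compound 2 to compound 4 (0.09 log units; that floor lies within the scatter) is expected to be small, in no firm direction, and within the scatter of repeated measurements, since compound 2 itself sits at the limit and compound 3 shows only weak activity with a different arrangement. Compound 4 is therefore estimated at 80000 nM in this assay, with a range from 20000 nM to 300000 nM, and it is expected that a limit rather than a number may again be reported.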

Compound 4, half-maximal inhibitory concentration: 62000 nM
Beside the measured number, compound 4's estimate is 1.3-fold (0.11 log units) above it; measured number inside the range.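

Compound 2 gives > 100000 nM in this assay, which is a limit of the assay and not a number. Setting 3-hydroxyphenyl in place of 4-methylphenyl on a sulfonyl sulfur gives the first step that can be read at this position, an at least 1.6-fold lower number from compound 2 to compound 4 (0.20 log units; that floor lies within the scatter), and it replaces that limit with a measured number. The step is only a floor and that floor lies within the scatter, so the change may be small or much larger, and its true size stays unknown because one end of it is a limit: the limit of > 100000 nM in this assay, at which 2 of the 4 values shown sit.

The compounds shown leave open whether this step comes from gaining the hydroxyl or from losing the methyl, and whether the hydroxyl would give the same result elsewhere on the ring. They also do not tell what an amine or a carboxylic acid in place of that hydroxyl would give in this assay, or whether a methoxy group would keep the number that the hydroxyl gives.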